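The source may hold more compounds than are shown below. What is called first, only, known or untested is meant among the compounds shown, and "the series" means these compounds.

Working notes on the series. Among the compounds with values here, compound 1 `Fc1ccc2ncnc(Nc3cccc(Cl)c3)c2c1` is the one member with a number: in a functional assay on HEK293 cells for antagonist activity at metabotropic glutamate receptor 5 (Rattus norvegicus), read by calcium flux (a lower number here means a stronger inhibitor, a higher number a weaker inhibitor), compound 1 gives 311 nM. Compound 2 `Clc1ccc2ncnc(NCc3ccccc3)c2c1` returns only a limit of this assay, > 30000 nM. Compound 3 `Clc1cccc(CNc2ncnc3ccc(Cl)cc23)c1` likewise returns only a limit, > 30000 nM. The change hydrogen in place of chloro on an aromatic carbon thus gave a step that the two limits leave unreadable from compound 3 to compound 2, unreadable because of the limit of > 30000 nM in this assay, at which 2 of the 3 values shown sit. How the core of compound 1 differs from that of compound 3 is not broken down here. Compound 4 `Fc1ccc2ncnc(Nc3ccccc3)c2c1` carries the same change, (hydrogen in place of chloro on an aromatic carbon), made on compound 1. Within the data shown here, since the only measured instance tells nothing of size, the expectation for compound 4 rests on compound 1 at 311 nM alone, with a step of a 2.3-fold higher number from compound 1 to compound 4 (0.35 log units; beyond the scatter) expected in this assay. Compound 4 is therefore estimated at 700 nM, expected between 150 nM and 3500 nM.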

Compound 4, half-maximal inhibitory concentration: > 10000 nM
Compound 4: only a limit was reported (the forecaster's own chance of this, stated with the estimate: 10%); middle value at least 14-fold (1.15 log units) away from the limit.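

On the core of compound 1, hydrogen in place of chloro on an aromatic carbon gave an at least 32-fold higher number from compound 1 to compound 4 (1.50 log units; beyond the scatter) in this assay, so the chloro counts heavily there. That step has a floor and no upper end, because compound 4 returns only a limit: the limit of > 10000 nM in this assay, at which 1 of the 4 values shown sits. Whether the change carries the same size from one core to another is not shown, because the step from compound 3 to compound 2 cannot be read: the limit of > 30000 nM in this assay, at which 2 of the 4 values shown sit.

The compounds shown leave open whether a group other than chloro on that aromatic carbon, such as methyl, methoxy or nitrile, would keep the activity of compound 1. Also open, going by these compounds, is whether any such group would give a readable number on the core of compound 3.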